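This account rests on a few compounds, and the source may have more. Where it says the series, first, only, none or still open, it means among the compounds named here.

Measured in a functional assay on P388 cells (Mus musculus) for cytotoxicity; a lower number here means that less compound is needed, a higher number that more compound is needed for the effect:
compound 1 `CS(=O)(=O)Oc1cc(-c2ccccc2)nc2ccccc12` — compound 1 gives > 10 ug/mL, a limit of the assay.
compound 2 `CC(C)Oc1cc(-c2ccccc2)nc2ccccc12` — compound 2 gives > 10 ug/mL, a limit of the assay.
compound 3 `c1ccc(COc2cc(-c3ccccc3)nc3ccccc23)cc1` — compound 3 gives > 10 ug/mL, a limit of the assay.

Compound 3 therefore stands at the limit of > 10 ug/mL in this assay, at which 3 of the 3 values shown sit, and no order among the three can be read. Compound 4 `CCCOc1cc(-c2ccccc2)nc2ccccc12` differs from compound 3 by ethyl in place of phenyl on a saturated chain carbon bound to an oxygen on an aromatic ring. Within the data shown here, the steps that bear on this are a step that the two limits leave unreadable from compound 2 to compound 3 and a step that the two limits leave unreadable from compound 1 to compound 3, and also a step that the two limits leave unreadable from compound 1 to compound 2; none of them gives a readable size, so no direction can be taken from them. Compound 4 is therefore expected to remain at the limit, with an expected step that the limit leaves unreadable from compound 3 to compound 4. Compound 4 is estimated at 20 ug/mL, within 8 ug/mL to 60 ug/mL.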

Compound 4, half-maximal effective concentration: 6.9 ug/mL
Estimate against measurement, compound 4: 2.9-fold (0.46 log units) above; measured number below the stated range.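

In this assay, among these compounds, the place on the oxygen on an aromatic ring now yields a readable number for the first time, with propyl in compound 4, while the other groups stay at the limit: (the limit of > 10 ug/mL in this assay, at which 3 of the 4 values shown sit). The new steps (an at least 1.4-fold lower number from compound 3 to compound 4 (0.16 log units; that floor lies within the scatter)) and (an at least 1.4-fold lower number from compound 2 to compound 4 (0.16 log units; that floor lies within the scatter)) and (an at least 1.4-fold lower number from compound 1 to compound 4 (0.16 log units; that floor lies within the scatter)) are floors only. Each floor lies within the scatter, so propyl is not yet shown to differ beyond it from benzyl, isopropyl or methylsulfonyl, and the steps among compound 1, compound 2 and compound 3 cannot be read.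

As far as these compounds go, whether a longer chain such as butyl, or an amine at the chain end, would shift the number remains open.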